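The compounds below may be only part of what the source reports. "The series", "measured", "known", "first", "only" and "open" are said of these compounds alone.

Of the compounds shown here, two have been tested so far in a functional assay on HCT-116 cells (Homo sapiens) for inhibition, read by sulforhodamine B assay, with a stated time of 48 h, tested at 10 uM; a higher number here means more inhibition at the concentration tested (going by the name of the read-out), a lower number less inhibition. Compound 1 `c1ccc2c(-c3cn4ccnc4c(-c4ccc5ncn(C6CCCCC6)c5c4)n3)cccc2c1` gives 17.9%. Compound 2 `CC(=O)c1ccc(-c2cn3ccnc3c(-c3ccc4ncn(C5CCCCC5)c4c3)n2)cc1` gives 15.9%. For the measured compounds named here, the one measured step, a number 2 percentage points lower from compound 1 to compound 2 (within the scatter), exchanges the whole aryl group at one end of the shared core, and the two numbers are too close to be told apart. Compound 2 therefore stands lowest of the two, with compound 1 the nearest neighbour, though the gap between them is within the scatter and carries no order.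

Compound 3 `Clc1ccc(-c2cn3ccnc3c(-c3ccc4ncn(C5CCCCC5)c4c3)n2)cc1` is the next compound to be measured. It differs from compound 2 by a single exchange on the aryl ring: chloro in place of acetyl on an aromatic carbon. Going by the values given here, no measured step tests this particular exchange. Among the compounds with values here, the only step known, from compound 1 to compound 2, replaced a much larger group than the one exchanged here and still moved the read-out by a negligible amount, and both known values are low. On that basis compound 3 is expected to give 16%, within 4% to 32%, so the step of a number 0.1 percentage points higher from compound 2 to compound 3 (within the scatter) is expected to stay within the scatter.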

Compound 3, a percentage reported as inhibition, at one concentration (the size of the read-out at that concentration, not a potency): 7.34%
Beside the measured number, compound 3's estimate is 8.7 percentage points above it, within the range that was stated.
By their numbers in this assay, from the lowest: compounds 3, 2 and 1 (each within the scatter of the next, the first and the last beyond it).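

In this assay, for the compounds shown here, chloro is the first group tested in place of acetyl on this aromatic carbon, para to a large group, and the step is a number 8.6 percentage points lower from compound 2 to compound 3 (within the scatter) so this smaller exchange of one heavy atom for three cannot be separated from no change at all. Going by these compounds alone, the comparison with the naphthalen-1-yl group says more, since the step is a number 10.6 percentage points lower from compound 1 to compound 3 (beyond the scatter) and is the first to clear the scatter, which shows that the aryl group at this end of the shared core can alter the read-out, though only modestly, while 4-acetylphenyl in compound 2 separates from neither of the other two compounds. Nothing available explains this difference between the aryl groups.

The compounds shown carry only three aryl groups at this place, so it stays open how the same ring would read with an amine, a carboxylic acid or a methoxy group in place of chloro. As far as these compounds go, it also stays open whether any group here can give much more inhibition than compound 1 does with 17.9% at this single concentration.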